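Cyclopropane amide series: inverting one ring stereocentre

The compounds below may be only part of what the source reports. "The series", "measured", "known", "first", "only" and "open" are said of these compounds alone.

Measured so far in a functional assay on HeLa cells (Homo sapiens) for cytotoxicity, read by MTT assay, with a stated time of 48 h; a higher number here means a weaker inhibitor, a lower number a stronger inhibitor:
compound 1 `CCOC(=O)[C@]1(C(=O)Nc2ccccc2)C[C@H]1c1cc(OC)c(OC)c(OC)c1` gives > 100000 nM, a limit of this assay.
compound 2 `CCOC(=O)[C@]1(C(=O)NCc2ccc(C)cc2)C[C@H]1c1cc(OC)c(OC)c(OC)c1` gives 28500 nM.
compound 3 `CCOC(=O)[C@]1(C(=O)Nc2ccccc2Cl)C[C@H]1c1cc(OC)c(OC)c(OC)c1` gives 42400 nM.

Compound 1 reaches only the limit of this assay, so its entry is a bound rather than a number. Of the two numbers, compound 2 is the lowest; its nearest neighbour is compound 3, and a 1.5-fold higher number from compound 2 to compound 3 (0.17 log units; within the scatter) sits within the scatter, so the two cannot be ordered. Against compound 1 the steps are an at least 3.5-fold lower number from compound 1 to compound 2 (0.54 log units; beyond the scatter) and an at least 2.3-fold lower number from compound 1 to compound 3 (0.37 log units; beyond the scatter), both beyond the scatter, but both rest on the limit of > 100000 nM in this assay, at which 1 of the 3 values shown sits, and so carry only a lower bound on their size.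

Compound 4 `CCOC(=O)[C@]1(C(=O)NCc2ccc(C)cc2)C[C@@H]1c1cc(OC)c(OC)c(OC)c1` has not yet been measured in this assay. Relative to compound 2 the change is: the two compounds have the same atoms and bonds and differ only in configuration as drawn: 1 of 2 stereo elements differ; a stereocentre at a saturated ring carbon is drawn S in compound 2 and R in compound 4. Within the data shown here, none of the measured steps touches configuration; each of them alters the group on the amide-type nitrogen while the ring configuration is kept. Among the measured compounds shown here, no measured step therefore bears on this change, and no direction can be drawn from the series. The working expectation is a step of a 1.1-fold higher number from compound 2 to compound 4 (0.02 log units; within the scatter), that is none beyond the scatter, with wide uncertainty in both directions. For compound 4 the expected value in this assay is 30000 nM, with a range from 8000 nM to 150000 nM.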

Compound 4, half-maximal inhibitory concentration: > 100000 nM
Compound 4: no number, only a limit; the forecaster's own chance of this, stated with the estimate: 25%; at least 3.3-fold (0.52 log units) between middle value and limit.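

Among these compounds, compound 2 and compound 4 give the first reading on configuration, as every earlier step altered the group on the amide-type nitrogen, whereas here the 4-methylbenzyl amide is kept and only one ring stereocentre changes, giving an at least 3.5-fold higher number from compound 2 to compound 4 (0.54 log units; beyond the scatter). This step can be assigned to that stereocentre alone in this assay, because no other structural difference exists: the fact that compounds 2 and 4 differ only in the configuration as drawn. In this assay compound 4 gives > 100000 nM, which is a limit and not a number, so the step fixes a direction and a lower bound on its size, not its full size: the limit of > 100000 nM in this assay, at which 2 of the 4 values shown sit.

The compounds shown leave open whether inverting this stereocentre has a comparable effect with 2-chlorophenyl on the amide-type nitrogen, and what inverting the second stereo element, alone or together with this one, would do. They also leave open whether this ring configuration still matters when the ethyl ester, constant across all four compounds, is replaced by a carboxylic acid or a primary amide.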